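This account rests on a few compounds, and the source may have more. Where it says the series, first, only, none or still open, it means among the compounds named here.

Working notes on the series. The shared core carries an amide whose nitrogen substituent is varied. Compound 1 `COc1ccc(-c2nc3c(C(=O)NCCCO)cccc3[nH]2)cc1OC` gives 46 uM in an ADME assay on Vero cells (Chlorocebus sabaeus) for cytotoxicity; on this read-out higher numbers stand for lower toxicity in this test and lower numbers for higher toxicity in this test. Compound 2 `CCC(CC)NC(=O)c1cccc2[nH]c(-c3ccc(OC)c(OC)c3)nc12` gives 2.23 uM in this assay. Going by the values given here, compound 3 `COc1ccc(-c2nc3c(C(=O)Nc4c[nH]cn4)cccc3[nH]2)cc1OC` gives 306 uM in this assay, the highest of the three numbers measured so far; the nearest is a 6.7-fold higher number from compound 1 to compound 3 (0.82 log units; beyond the scatter) and the furthest is a 140-fold higher number from compound 2 to compound 3 (2.14 log units; beyond the scatter).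

Compound 4 `COc1ccc(-c2nc3c(C(=O)Nc4nc(C#N)c(C#N)[nH]4)cccc3[nH]2)cc1OC` is not yet measured. It differs from compound 3 by 4,5-dicyano-1H-imidazol-2-yl in place of 1H-imidazol-4-yl on an amide-type nitrogen. The measured steps that bear on this site are both replacements of the whole group on the amide nitrogen: a 6.7-fold higher number from compound 1 to compound 3 (0.82 log units; beyond the scatter) and a 140-fold higher number from compound 2 to compound 3 (2.14 log units; beyond the scatter). Among the compounds with values here, neither step changes the substitution of an imidazole that is already in place; the data hold no pair of that kind. The expectation for this assay is therefore a step of a 1.5-fold lower number from compound 3 to compound 4 (0.18 log units; within the scatter), with no strong ground for a direction beyond the scatter. Compound 4 is estimated at 200 uM, with a range from 60 uM to 600 uM.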

Compound 4, half-maximal toxic concentration: 43.1 uM
Beside the measured number, compound 4's estimate is 4.6-fold (0.67 log units) above it; measured number outside the range, below it.
By their numbers in this assay, from the lowest: compound 2; then compounds 4 and 1 (each within the scatter of the next); then compound 3.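

In this assay, the imidazole on the amide-type nitrogen does not by itself secure the high number of compound 3: 4,5-dicyano-1H-imidazol-2-yl gives a 7.1-fold lower number from compound 3 to compound 4 (0.85 log units; beyond the scatter) and so shows that this position responds to changes within the imidazole group, not only to replacement of the whole group. The new group still stands well clear of pentan-3-yl, with a 19-fold higher number from compound 2 to compound 4 (1.29 log units; beyond the scatter) and, against the 3-hydroxypropyl group, a 1.1-fold lower number from compound 1 to compound 4 (0.03 log units; within the scatter). No available evidence gives a reason for these steps.

The compounds shown leave open how much of the step from compound 3 belongs to the two nitrile groups and how much to the change from the 1H-imidazol-4-yl to the 1H-imidazol-2-yl attachment. An unsubstituted 1H-imidazol-2-yl, a single nitrile, or methyl groups in place of the nitriles would bear on that question.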